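This account rests on a few compounds, and the source may have more. Where it says the series, first, only, none or still open, it means among the compounds named here.

The shared core of compound 1, `NC[C@@H]1CCCc2cc(S(=O)(=O)c3c[nH]c4ccccc34)ccc21`, carries an aminomethyl substituent on its saturated ring, and in an assay on isolated protein for displacement of a labelled ligand from 5-hydroxytryptamine receptor 6 (Homo sapiens) (on this read-out lower numbers stand for stronger inhibition and higher numbers for weaker inhibition), compound 1 gives 0.0501 nM. Compound 2, `CN(C)S(=O)(=O)NC[C@@H]1CCCc2cc(S(=O)(=O)c3cccc(F)c3)ccc21`, and compound 3, `N=C(N)NC(=O)C[C@@H]1CCCc2cc(S(=O)(=O)c3cccc(F)c3)ccc21`, both bear a fluorophenylsulfonyl group on the same core and differ from each other only on the saturated chain carbon bound to the saturated ring carbon. In this assay compound 2 gives 2 nM and compound 3 gives 0.631 nM. Among the three measured compounds compound 2 has the highest number: compound 3 is its nearest neighbour and compound 1 its furthest.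

Compound 4, `CN(C[C@@H]1CCCc2cc(S(=O)(=O)c3cccc(F)c3)ccc21)C(N)=O`, is reached from compound 2 by a single change: carbamoyl(methyl)amino in place of (dimethylsulfamoyl)amino on a saturated chain carbon bound to a saturated ring carbon. Among the measured compounds shown here, the one measured step at this position, a 3.2-fold lower number from compound 2 to compound 3 (0.50 log units; beyond the scatter), shows that replacing the (dimethylsulfamoyl)amino group of compound 2 with a different small substituent here gave a modestly lower number. For the measured compounds named here, no step to compound 4 itself has been measured, so the direction for compound 4 can only be drawn from that neighbour. A comparable outcome is expected, so the step of a 2.0-fold lower number from compound 2 to compound 4 (0.30 log units; within the scatter) is estimated to be modest and downward. For compound 4 in this assay a value of 1 nM is expected, with a range from 0.3 nM to 3.2 nM.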

Compound 4, inhibition constant: 39.8 nM
Estimate against measurement, compound 4: 40-fold (1.60 log units) below; the measured number lies above the stated range.
By their numbers in this assay, from the lowest: compound 1; then compound 3; then compound 2; then compound 4.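

In this assay, among the compounds shown here, the substituent on a saturated chain carbon bound to a saturated ring carbon turns out to move the number upward as well as downward: carbamoyl(methyl)amino in place of (dimethylsulfamoyl)amino gives a 20-fold higher number from compound 2 to compound 4 (1.30 log units; beyond the scatter), opposite in direction to the only earlier step at this place. Against the group carried by compound 3, the change is larger still, at a 63-fold higher number from compound 3 to compound 4 (1.80 log units; beyond the scatter), so this single place now accounts for a wide spread among the fluorophenylsulfonyl compounds. Heavy-atom count does not order these results, as compound 2 carries the largest of the three groups yet lies between compound 3 and compound 4, which carries the smallest. No measurement shown here accounts for the rise in the number.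

As far as these compounds go, it remains open whether the higher number goes with the carbamoyl group or with the methyl on its nitrogen, which an unsubstituted ureido group or a carboxylic acid at this place might help to separate. From the compounds shown here alone, compound 1 differs from the others in more than one place, so how its aminomethyl substituent would read with the fluorophenylsulfonyl group also stays open.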